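The compounds below may be only part of what the source reports. "The series", "measured", "known", "first", "only" and "open" are said of these compounds alone.

Of the compounds shown here, two with a shared core have been measured. Compound 1 `Cc1cc(C#N)cc(C)c1Oc1cc(Nc2ccc(C#N)cc2)c(N)cc1CNCCCO` gives 236 ug/mL in a physicochemical assay for solubility, read by HPLC, at pH 7.4; on this read-out higher numbers stand for higher solubility and lower numbers for lower solubility. Among the measured compounds shown here, compound 2 `CC(=O)OCc1cc(N)c(Nc2ccc(C#N)cc2)cc1Oc1c(C)cc(C#N)cc1C` gives 0.2 ug/mL in this assay and stands lowest of the two numbers; the single measured step, a 1200-fold lower number from compound 1 to compound 2 (3.07 log units; beyond the scatter), separates it from compound 1. Compound 3 `CC(=O)OCc1cc(N)c(Nc2ccc(C#N)cc2)cc1Oc1c(C)cc(/C=C/C#N)cc1C` has not yet been measured. It differs from compound 2 by 2-cyanoethenyl in place of cyano on an aromatic carbon. For the measured compounds named here, no measured step bears on this change: the one known step alters a group on a saturated chain carbon, whereas here the cyano group on the aromatic ring is lengthened. There is nothing comparable to draw on, so the expectation rests on compound 2 alone. Compound 3 is expected to give about 0.15 ug/mL in this assay, within a range from 0.03 ug/mL to 0.6 ug/mL. The expected step is a 1.3-fold lower number from compound 2 to compound 3 (0.12 log units; within the scatter), not beyond the scatter.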

Compound 3, solubility: 0.49 ug/mL
For compound 3 the middle estimate is 3.3-fold (0.51 log units) below the measured one; low and high end bracket the measured number.
By their numbers in this assay, from the lowest: compound 2; then compound 3; then compound 1.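

Replacing cyano with 2-cyanoethenyl on the aromatic carbon gives a 2.5-fold higher number from compound 2 to compound 3 (0.39 log units; beyond the scatter) in this assay, so the change adds two heavy atoms and a double bond while the hydrogen-bond donor and acceptor counts stay the same. Among the compounds shown here, this is the first view of this position, meta to two methyl groups and para to a large group, and it shows that a change here can move the read-out, though far less than a 1200-fold lower number from compound 1 to compound 2 (3.07 log units; beyond the scatter) on the saturated chain carbon. Nothing measured here accounts for the step.

As far as these compounds go, this change is seen in one pair only, so it remains open whether it would act the same way in a compound carrying the (3-hydroxypropyl)amino chain of compound 1. From the compounds shown here alone, how an amine or a carboxylic acid at this position would read also remains open.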